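A few compounds are considered here, and "the series" means these few. Any claim that something is new, unique, unknown or untested is made for them only; others in the source may bear on it.

Measured so far in a functional assay on B16 cells (Mus musculus) for antiproliferative activity, with a stated time of 72 h; a lower number here means a stronger inhibitor, a higher number a weaker inhibitor:
- compound 1 `OC[C@H]1O[C@@H](n2cnc3c(NCc4ccccc4F)ncnc32)[C@H](O)[C@@H]1O`: > 166000 nM
- compound 2 `OC[C@H]1O[C@@H](n2cnc3c(NCc4ccc(F)cc4)ncnc32)[C@H](O)[C@@H]1O`: "not determined" (no result reported)

In this assay compound 2 gives "not determined" (no result reported), so it has no number of its own to stand on. Among the measured compounds shown here, the only other reading is that of compound 1, (the limit of > 166000 nM in this assay, at which 1 of the 2 values shown sits). For compound 1 this is a limit of the assay and not a number.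

Compound 3 `OC[C@H]1O[C@@H](n2cnc3c(NCc4ccc(Cl)cc4)ncnc32)[C@H](O)[C@@H]1O` takes chloro in place of fluoro on an aromatic carbon, para to a large group: chloro in place of fluoro on an aromatic carbon. For the measured compounds named here, with no number for compound 2, no measured step can serve as a guide. A small step is expected in this assay, none beyond the scatter, with no direction favoured, and a reading of compound 3 as a limit is quite possible. For compound 3 the estimated value is 70000 nM, with an expected range of 12000 nM to 200000 nM.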

Compound 3, half-maximal inhibitory concentration: > 166000 nM
Compound 3: only a limit was reported; the forecaster's own chance of this, stated with the estimate: 50%; at least 2.3-fold (0.37 log units) between middle value and limit.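

In this assay compound 3 gives > 166000 nM, a limit of the assay and not a number. Compound 1 also stands at a limit, so no step can be read between compound 1 and compound 3. Still open, on these data alone, is whether any compound on the shared core reaches a measurable value in this assay.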